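Pyridinylmethyl in place of carboxythiophenylmethyl on the ring amine

The compounds below may be only part of what the source reports. "The series", "measured", "known", "first", "only" and "open" are said of these compounds alone.

Working notes on a small set of substituted piperidines carrying a dichlorophenyl ether and a phenyl group on the shared core. In an assay on isolated protein for activation of cGMP-dependent protein kinase 1 (Homo sapiens), read by ADP-Glo, with stated times of 120 min and 40 min (a lower number here means that less compound is needed, a higher number that more compound is needed for the effect), compound 1 `O=C(O)c1ccc(CN2CCC[C@H](OCc3cc(Cl)cc(Cl)c3)[C@@H]2c2ccccc2)s1` gives 76000 nM, the highest of the two numbers at hand. Compound 2 `OC[C@@H](O[C@H]1CCCN(Cc2ncc[nH]2)[C@H]1c1ccccc1)c1cc(Cl)cc(Cl)c1` shows a different substituent on the ring nitrogen and a hydroxymethyl on the ether carbon; in this assay compound 2 gives 7000 nM, which stands a clear distance below the number for compound 1 and beyond the scatter. For the measured compounds named here, no step between two measured compounds that differ in one place has been recorded, so the two values only bracket the range seen so far.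

Compound 3 `Clc1cc(Cl)cc(CO[C@H]2CCCN(Cc3cccnc3)[C@H]2c2ccccc2)c1` differs from compound 1 as follows: pyridin-3-yl in place of 5-carboxythiophen-2-yl on a saturated chain carbon bound to an amine nitrogen in a ring. With the carboxylic acid gone and a smaller six-membered aromatic ring entering, a moderate shift toward a lower number is expected, though the direction is not secured by any measured pair. The step from compound 1 to compound 3 is estimated as a 1.9-fold lower number from compound 1 to compound 3 (0.28 log units; within the scatter). In this assay compound 3 is expected to give 40000 nM, within a range from 10000 nM to 150000 nM.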

Compound 3, half-maximal effective concentration: 112000 nM
Beside the measured number, compound 3's estimate is 2.8-fold (0.45 log units) below it; measured number inside the range.
By their numbers in this assay, from the lowest: compound 2; then compounds 1 and 3 (each within the scatter of the next).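

In this assay, for the compounds shown here, pyridin-3-yl in place of 5-carboxythiophen-2-yl on a saturated chain carbon bound to an amine nitrogen in a ring gives a 1.5-fold higher number from compound 1 to compound 3 (0.17 log units; within the scatter), the first step that can be read as a change in one place. This single pair shows that the 5-carboxythiophen-2-yl group, with its carboxylic acid, can be exchanged at this place for pyridin-3-yl with no difference that this read-out can resolve, even though the two groups differ in ring size, heavy atoms and hydrogen-bond donors. No measurement at hand accounts for this outcome or says which feature of either group matters.

Still open, from the compounds shown here alone, is whether any group at this place moves the number beyond the scatter, for example a plain benzyl group, a dimethylamino group or a longer chain carrying the carboxylic acid. Going by these compounds, compound 2 differs from compound 1 in more than one place, so the separate contributions of its imidazole-bearing substituent and its hydroxymethyl also remain open.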